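A vinyl group on the saturated ring of compound 1

This account rests on a few compounds, and the source may have more. Where it says the series, first, only, none or still open, it means among the compounds named here.

In a functional assay on MDA-MB-435 cells (Homo sapiens) for inhibition, read by sulforhodamine B assay, with a stated time of 48 h (a lower number here means a stronger inhibitor, a higher number a weaker inhibitor), compound 1 (`COc1ccc(N(C)c2nc(N)nc3c2CCC3)cc1`) gives 16.7 nM as the second highest of three numbers. Compound 3 (`CCOc1ccc(N(C)c2nc(N)nc3c2CCC3)cc1`) stands at 20.3 nM and compound 2 (`COc1ccc(N(C)c2nc(C)nc3c2CCC3)cc1`) at 7 nM in that series. Compound 4 (`C=CC1Cc2nc(N)nc(N(C)c3ccc(OC)cc3)c2C1`) has vinyl in place of hydrogen on a saturated ring carbon of a five-membered non-aromatic ring of carbon only. Neither measured step touches that place. The modest 2.4-fold lower number from compound 1 to compound 2 (0.38 log units; beyond the scatter) comes with methyl in place of amino on an aromatic carbon. The step of a 1.2-fold higher number from compound 1 to compound 3 (0.08 log units; within the scatter) stays within the scatter and comes with methyl in place of hydrogen on a saturated chain carbon bound to an oxygen on an aromatic ring. Both steps are small, but they guide this change only weakly, and the data hold no earlier substitution on the saturated ring. A modest rise is tentatively expected, and the estimated step is a 1.7-fold higher number from compound 1 to compound 4 (0.22 log units; within the scatter) with its direction uncertain. Compound 4 is expected at 28 nM within a range of 9 nM to 90 nM in this estimate.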

Compound 4, half-maximal inhibitory concentration: 205 nM
Beside the measured number, compound 4's estimate is 7.3-fold (0.86 log units) below it; measured number above the stated range.
By their numbers in this assay, from the lowest: compound 2; then compounds 1 and 3 (each within the scatter of the next); then compound 4.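

In this assay, among these compounds, the saturated ring turns out to be far more sensitive to change than the two places varied earlier: vinyl in place of hydrogen gives a 12-fold higher number from compound 1 to compound 4 (1.09 log units; beyond the scatter), whereas the earlier steps were only a 2.4-fold lower number from compound 1 to compound 2 (0.38 log units; beyond the scatter) and a 1.2-fold higher number from compound 1 to compound 3 (0.08 log units; within the scatter). Among the compounds shown here, it is the first change in this set to weaken the compound by a large step, and it does so with only two heavy carbon atoms entering, on a saturated ring carbon of the core. No measurement shown here accounts for this loss.

On these data alone, a single compound cannot show whether the loss belongs to vinyl itself or to any group at this ring carbon, so methyl, ethyl or hydroxyl there remain open. Also open, as far as these compounds go, is whether vinyl would weaken compound 2 by a similar step.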